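The source may report more compounds than this note shows. Statements on the series, on what has been measured and on what is new or still open speak of the compounds shown alone.

Compound 1 `C=C1[C@@H](OC(C)=O)C[C@@H]2[C@](C)(COC=O)[C@H](OC(C)=O)CC[C@@]2(C)[C@@H]1C[C@@H](Nc1cccc(F)c1)C1=CCOC1=O` gives 28600 nM
Compound 2 `C=C1[C@@H](OC(C)=O)C[C@@H]2[C@](C)(CO[Si](C)(C)C(C)(C)C)[C@H](OC(C)=O)CC[C@@]2(C)[C@@H]1C/C=C1/C(=O)OC[C@H]1OC(C)=O` gives 5020 nM

In a functional assay on KB cells (Homo sapiens) for cytotoxicity, read by sulforhodamine B assay (a higher number here means a weaker inhibitor, a lower number a stronger inhibitor), compound 1 stands highest at 28600 nM and is the weaker of the pair, with compound 2 lower at 5020 nM. The gap between the two lies beyond the scatter. Compound 3 `C=C1[C@@H](OC(C)=O)C[C@@H]2[C@](C)(COC=O)[C@H](OC(C)=O)CC[C@@]2(C)[C@@H]1C[C@@H](Nc1ccc(OC)cc1)C1=CCOC1=O` keeps the core of compound 1 and carries 4-methoxyphenyl in place of 3-fluorophenyl on an amine nitrogen. Among the measured compounds shown here, no measured pair differs in one place only, so nothing measured sizes this change, and no shift beyond the scatter is expected. The estimated step (a 1.3-fold lower number from compound 1 to compound 3 (0.11 log units; within the scatter)) stays small. For compound 3 the expected value is 22000 nM within a range of 9000 nM to 50000 nM in this estimate.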

Compound 3, half-maximal inhibitory concentration: 32700 nM
The estimate for compound 3 lay 1.5-fold (0.17 log units) below the measured number; the measured number falls inside the stated range.
By their numbers in this assay, from the lowest: compound 2; then compounds 1 and 3 (each within the scatter of the next).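

In this assay, among the compounds shown here, this is the first comparison that changes only one place, and it reads a 1.1-fold higher number from compound 1 to compound 3 (0.06 log units; within the scatter). Putting 4-methoxyphenyl in place of 3-fluorophenyl on the amine nitrogen therefore leaves the cytotoxicity reading indistinguishable, even though the two groups differ in their substituent and in where it sits on the ring. Nothing measured here explains this result.

From the compounds shown here alone, whether a pyridine ring, an unsubstituted phenyl or a longer alkyl chain on this nitrogen would move the number beyond the scatter remains open.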